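The source may report more compounds than this note shows. Statements on the series, on what has been measured and on what is new or still open speak of the compounds shown alone.

In a functional assay on A549 cells (Homo sapiens) for antiproliferative activity, read by MTT assay, with a stated time of 48 h (on this read-out higher numbers stand for weaker inhibition and lower numbers for stronger inhibition), compound 1 `COc1cc(C(=O)/C=C/c2c[nH]c3ccccc23)cc(SC)c1OC` gives 152 nM and compound 2 `COc1ccc2c(/C=C/C(=O)c3cc(OC)c(OC)c(SC)c3)cn(C)c2c1` gives 156 nM. Compound 2 therefore stands level with compound 1, the two numbers lying within the usual scatter of each other. Compound 3 `COc1cc(C(=O)/C=C/c2cn(C)c3ccccc23)cc(SC)c1OC` has not yet been measured. It departs from compound 2 by one change, hydrogen in place of methoxy on an aromatic carbon. Within the data shown here, no measured pair isolates this change, so only a small shift toward weaker inhibition is expected, perhaps none beyond the scatter. The expected step is a 1.2-fold higher number from compound 2 to compound 3 (0.09 log units; within the scatter). For compound 3, the estimate is 190 nM, with an expected range from 65 nM to 550 nM.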

Compound 3, half-maximal inhibitory concentration: 188 nM
Beside the measured number, compound 3's estimate is 1.0-fold (0.00 log units) above it; low and high end bracket the measured number.
By their numbers in this assay, from the lowest: compounds 1, 2 and 3 (each within the scatter of the next).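

In this assay hydrogen in place of methoxy on this aromatic carbon gives a 1.2-fold higher number from compound 2 to compound 3 (0.08 log units; within the scatter) and so the two groups read alike at this position. Methyl in place of hydrogen on the aromatic nitrogen gives a 1.2-fold higher number from compound 1 to compound 3 (0.09 log units; within the scatter) and so those two groups also read alike. Nothing measured here offers an explanation for either result. As far as these compounds go, whether an amine or a carboxylic acid on this aromatic carbon would also read alike stays open. So does the effect of a longer chain, such as propyl, on the nitrogen.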